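Replacing a pyrazole with a triazole on a urea inhibitor

A few compounds are considered here, and "the series" means these few. Any claim that something is new, unique, unknown or untested is made for them only; others in the source may bear on it.

Two compounds share one core: an aryl urea with a cycloheptyl group and a benzyl arm carrying a small aromatic ring. Compound 1 `Cc1cc(C)c(NC(=O)N(Cc2ccc(-c3cc[nH]n3)cc2)C2CCCCCC2)c(C)c1` is measured in an assay on microsomes from intestine for inhibition of acyl-CoA:cholesterol acyltransferase (Oryctolagus cuniculus) (a lower number here means a stronger inhibitor, a higher number a weaker inhibitor), and gives 52 nM. Compound 2 `Cc1cc(C)c(NC(=O)N(Cc2ccc(-c3cn[nH]c3)cc2)C2CCCCCC2)c(C)c1` gives 270 nM in this assay. For the measured compounds named here, of the two numbers, compound 2 holds the higher one, and the single step between them, a 5.2-fold higher number from compound 1 to compound 2 (0.72 log units; beyond the scatter), shows that moving the attachment point of the same ring already shifts the result beyond the scatter.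

Compound 3 `Cc1cc(C)c(NC(=O)N(Cc2ccc(-n3ccnn3)cc2)C2CCCCCC2)c(C)c1` has not yet been measured in this assay. It differs from compound 2 in one place: 1H-1,2,3-triazol-1-yl in place of 1H-pyrazol-4-yl on an aromatic carbon. Going by the values given here, the one step measured so far concerns the same ring region and was of modest size, so a step of comparable size is expected here too; its direction cannot be read from a single step. Compound 3 is therefore estimated at 350 nM, with a range from 100 nM to 1200 nM, meaning an expected step of a 1.3-fold higher number from compound 2 to compound 3 (0.11 log units; within the scatter).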

Compound 3, half-maximal inhibitory concentration: 42 nM
Beside the measured number, compound 3's estimate is 8.3-fold (0.92 log units) above it; measured number outside the range, below it.
By their numbers in this assay, from the lowest: compounds 3 and 1 (each within the scatter of the next); then compound 2.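

Swapping 1H-pyrazol-4-yl for 1H-1,2,3-triazol-1-yl gives a 6.4-fold lower number from compound 2 to compound 3 (0.81 log units; beyond the scatter) in this assay, so at this place, para to a large group, a low number is not confined to a pyrazole. Against 1H-pyrazol-3-yl the same triazole gives a 1.2-fold lower number from compound 1 to compound 3 (0.09 log units; within the scatter), which leaves the two rings level here, even though the triazole has 0 hydrogen-bond donors; a donor on this ring is therefore not needed for a number at this level, and compound 2, which has one, shows that a donor does not ensure it. No measurement shown here explains why these three rings rank as they do.

Still open, from the compounds shown here alone, is whether the result belongs to this particular arrangement of ring atoms, which a 1H-1,2,4-triazol-1-yl, an imidazol-1-yl or a tetrazolyl ring at the same place could test. Going by these compounds, it is also open how far the position tolerates something other than a five-membered aromatic ring, such as a carboxylic acid, an amine or a plain phenyl group.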